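The source may hold more compounds than are shown below. What is called first, only, known or untested is meant among the compounds shown, and "the series" means these compounds.

Compound 1 `CCOC(=O)c1cnc(C)nc1NN1C(=O)C=C(C)C1=O` gives 16000 nM in a functional assay on Jurkat cells for inhibition of nuclear factor NF-kappa-B complex (Homo sapiens) (a lower number here means a stronger inhibitor, a higher number a weaker inhibitor), the highest of the three numbers measured here: compound 3 `CCOC(=O)c1cnc(-c2ccc(F)cc2)nc1NN1C(=O)C=C(C)C1=O` stands nearest to it with 700 nM, and compound 2 `CCOC(=O)c1cnc(SC)nc1NN1C(=O)C=C(C)C1=O` stands furthest from it with 200 nM. Compound 4 `CCOC(=O)c1cnc(-c2ccc(Cl)s2)nc1NN1C(=O)C=C(C)C1=O` differs from compound 1 by 5-chlorothiophen-2-yl in place of methyl on an aromatic carbon. Among the compounds with values here, two measured steps bear on this change, both starting from compound 1: an 80-fold lower number from compound 1 to compound 2 (1.90 log units; beyond the scatter) and a 23-fold lower number from compound 1 to compound 3 (1.36 log units; beyond the scatter), each a large lowering. The group entering in compound 4 is an aromatic ring, as in compound 3, and brings a sulfur, as in compound 2. For compound 4 a large lowering is therefore expected, a 32-fold lower number from compound 1 to compound 4 (1.51 log units; beyond the scatter), and its value is estimated at 500 nM with a range from 100 nM to 2500 nM.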

Compound 4, half-maximal inhibitory concentration: 300 nM
The estimate for compound 4 lay 1.7-fold (0.22 log units) above the measured number; measured number inside the range.
By their numbers in this assay, from the lowest: compounds 2 and 4 (each within the scatter of the next); then compound 3; then compound 1.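

In this assay, the position between two ring nitrogen atoms accepts a five-membered aromatic ring as well as the 4-fluorophenyl group, with a large step from the methyl compound (a 53-fold lower number from compound 1 to compound 4 (1.73 log units; beyond the scatter)) and a modest further one between the two aromatic groups (a 2.3-fold lower number from compound 3 to compound 4 (0.37 log units; beyond the scatter)). The 5-chlorothiophen-2-yl and methylsulfanyl groups cannot be told apart (a 1.5-fold higher number from compound 2 to compound 4 (0.18 log units; within the scatter)), although only one of them carries a ring. Nothing available explains these steps.

Going by these compounds, whether the chlorine contributes remains open, as a thiophene without it would show. So does how an amine at this position would compare.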